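The source may report more compounds than this note shows. Statements on the series, on what has been measured and on what is new or still open speak of the compounds shown alone.

In an ADME assay on a cell-free system (plasma, Homo sapiens) for metabolic stability, read by LC-MS (on this read-out lower numbers stand for a shorter-lived compound and higher numbers for a longer-lived compound), compound 1 `CCCCOC(=O)c1cccc(-c2cc(C(=O)Nc3ccncc3)ccc2CN)c1` gives 0.367 h, the middle of three measured numbers: compound 2 `CC(C)OCCOC(=O)c1cccc(-c2cc(C(=O)Nc3ccncc3F)ccc2CN)c1` gives 0.1 h and compound 3 `NCc1ccc(C(=O)Nc2ccncc2F)cc1-c1cccc(C(=O)OCCO)c1` gives 1.35 h. Compound 4 `NCc1ccc(C(=O)Nc2ccncc2)cc1-c1cccc(C(=O)OCC2CCCC2)c1` keeps the core of compound 1 and carries one change, (cyclopentyl in place of propyl on a saturated chain carbon bound to an oxygen next to a carbonyl group), which also reads as butyl to cyclopentylmethyl. Going by the values given here, the only measured single-place step, a 14-fold higher number from compound 2 to compound 3 (1.13 log units; beyond the scatter), is large, but it swaps a different group, so it shows that the number can respond strongly without giving a direction for this change. Among the compounds with values here, no measured compound carries a cyclopentyl group, so the expected step is small, a 1.1-fold higher number from compound 1 to compound 4 (0.04 log units; within the scatter), within the scatter. For compound 4 the estimated half-life is 0.4 h, with an expected range of 0.15 h to 1 h.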

Compound 4, half-life: 0.517 h
For compound 4 the middle estimate is 1.3-fold (0.11 log units) below the measured one, within the range that was stated.
By their numbers in this assay, from the lowest: compound 2; then compounds 1 and 4 (each within the scatter of the next); then compound 3.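

In this assay the first step read on the chain of compound 1 is small (a 1.4-fold higher number from compound 1 to compound 4 (0.15 log units; within the scatter)), so replacing butyl with cyclopentylmethyl does not separate the two half-lives. Adding a five-membered carbon ring on this saturated chain carbon therefore leaves the reading indistinguishable from that of the open chain. Nothing available explains this outcome. Still open, as far as these compounds go, is how the half-life would read with a phenyl or tert-butyl group in place of the cyclopentyl, on the same core.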